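From oxan-4-yl to 1-methylpyrrolidin-2-yl on the amide

The source may report more compounds than this note shows. Statements on the series, on what has been measured and on what is new or still open speak of the compounds shown alone.

In a functional assay on A2780 cells (Homo sapiens) for antiproliferative activity, read by CellTiter-Glo, with a stated time of 4 days (on this read-out lower numbers stand for stronger inhibition and higher numbers for weaker inhibition), compound 3 (`C[C@H](NC(=O)C1CCOCC1)c1ccc(NC(=O)[C@H]2C[C@@H]2c2cccnc2)cc1`) reads 3 nM and so sits with compound 2 (`C[C@H](NC(=O)CC(F)(F)F)c1ccc(NC(=O)[C@H]2C[C@@H]2c2cccnc2)cc1`) at 5 nM and far from compound 1 (`CCC(=O)NCc1ccc(NC(=O)[C@H]2C[C@@H]2c2cccnc2)cc1`) at 405 nM on this scale. Compound 4 (`C[C@H](NC(=O)[C@@H]1CCCN1C)c1ccc(NC(=O)[C@H]2C[C@@H]2c2cccnc2)cc1`) carries 1-methylpyrrolidin-2-yl in place of oxan-4-yl on a carbonyl carbon. Among the measured compounds shown here, the one measured step at this place is a 1.7-fold lower number from compound 2 to compound 3 (0.22 log units; within the scatter) and it involves a different pair of groups, so it is only a thin guide. No step beyond the scatter is therefore expected in this assay for this change. The expected change is a 1.7-fold higher number from compound 3 to compound 4 (0.22 log units; within the scatter) in this estimate. Compound 4 is expected at 5 nM (estimated range 1.5 nM to 25 nM).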

Compound 4, half-maximal inhibitory concentration: 1 nM
The estimate for compound 4 lay 5.0-fold (0.70 log units) above the measured number; measured number outside the range, below it.
By their numbers in this assay, from the lowest: compound 4; then compounds 3 and 2 (each within the scatter of the next); then compound 1.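

In this assay, this position proves able to move the number beyond the scatter: a 3.0-fold lower number from compound 3 to compound 4 (0.48 log units; beyond the scatter), and a 5.0-fold lower number from compound 2 to compound 4 (0.70 log units; beyond the scatter), whereas the earlier step here stayed within it. The entering 1-methylpyrrolidin-2-yl has the same count of heavy atoms as oxan-4-yl, but a five-membered ring with nitrogen as its hetero atom. No measurement shown bears on why the number falls.

On these data alone, it stays open whether ring size, the ring nitrogen, its methyl group or the defined stereocentre carries the step. As far as these compounds go, how a pyrrolidin-2-yl without the methyl, or an open-chain dimethylaminomethyl group, would read on the same carbonyl carbon also stays open.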